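Adding a Methyl to a Fluorinated Acid: Compound 4

The source may report more compounds than this note shows. Statements on the series, on what has been measured and on what is new or still open speak of the compounds shown alone.

Among the three measured compounds, compound 2 `COc1ccc(F)c([C@H]2CC[C@H](COc3cccc([C@H](C4CC4)[C@H](F)C(=O)O)c3)CC2)c1` holds the highest number in a functional assay on HEK293 cells for agonist activity at Free fatty acid receptor 1 (Homo sapiens), read by FLIPR and calcium flux; a lower number here means that less compound is needed, a higher number that more compound is needed for the effect: compound 2 gives 54 nM. Its nearest neighbour is compound 1 `COc1ccc(F)c([C@H]2CC[C@H](COc3cccc([C@@H](CC(=O)O)C4CC4)c3)CC2)c1`, which in this assay gives 0.94 nM, and the furthest is compound 3 `COc1ccc(F)c([C@H]2CC[C@H](COc3cccc([C@H](C4CC4)[C@@](C)(F)C(=O)O)c3)CC2)c1`, which gives 0.25 nM. The single-point steps read a 57-fold higher number from compound 1 to compound 2 (1.76 log units; beyond the scatter) and a 220-fold lower number from compound 2 to compound 3 (2.33 log units; beyond the scatter), while a 3.8-fold lower number from compound 1 to compound 3 (0.58 log units; beyond the scatter) closes the triangle.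

Compound 4 `COc1ccc(F)c([C@H]2CC[C@H](COc3cccc([C@H](C4CC4)[C@](C)(F)C(=O)O)c3)CC2)c1` differs from compound 2 by 1-carboxy-1-fluoroethyl in place of carboxy(fluoro)methyl on a saturated chain carbon bound to an aromatic carbon and a saturated ring carbon. Compound 3 carries the same group, but with the opposite configuration at its stereocentre. Going by the values given here, the only measured step that bears directly on this change is a 220-fold lower number from compound 2 to compound 3 (2.33 log units; beyond the scatter), a large fall in the number; compound 4 asks whether the other configuration of the same group behaves alike. Among the compounds with values here, no measured pair shows how the two configurations of this group compare, so the expectation is hedged: the added methyl is expected to lower the number relative to compound 2, but with less certainty than compound 3 showed. Compound 4 is therefore expected to give 5 nM in this assay, within 0.5 nM to 50 nM. That expectation amounts to an 11-fold lower number from compound 2 to compound 4 (1.03 log units; beyond the scatter).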

Compound 4, half-maximal effective concentration: 6.1 nM
Compound 4: middle estimate off by 1.2-fold (0.09 log units), on the low side, and the stated range covers the measured number.
By their numbers in this assay, from the lowest: compound 3; then compound 1; then compound 4; then compound 2.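

In this assay, the added methyl lowers the number in both configurations, but by unequal amounts: an 8.9-fold lower number from compound 2 to compound 4 (0.95 log units; beyond the scatter), set against a 220-fold lower number from compound 2 to compound 3 (2.33 log units; beyond the scatter). The result also gives the first direct comparison of the two configurations of 1-carboxy-1-fluoroethyl, a 24-fold higher number from compound 3 to compound 4 (1.39 log units; beyond the scatter), and this gap can be assigned to configuration alone because nothing else separates the pair: the fact that compounds 3 and 4 differ only in the configuration as drawn

Measured against the carboxymethyl acid, the direction of the change therefore depends on configuration, with a 6.5-fold higher number from compound 1 to compound 4 (0.81 log units; beyond the scatter) but a 3.8-fold lower number from compound 1 to compound 3 (0.58 log units; beyond the scatter), so 1-carboxy-1-fluoroethyl in place of carboxymethyl does not by itself lower the number.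

The compounds shown leave open what a methyl without the fluorine would do on the saturated chain carbon bound to a carbonyl carbon, and whether a hydroxyl or a chlorine in place of the fluorine would preserve the same difference between configurations. They also leave open how the opposite configuration of the carboxy(fluoro)methyl group in compound 2 would compare, so the effect of configuration is known here only for the methylated pair.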